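Cyano to Bromo: What Solubility to Expect for Compound 3

A few compounds are considered here, and "the series" means these few. Any claim that something is new, unique, unknown or untested is made for them only; others in the source may bear on it.

Measured so far:
compound 1 `CCc1ccc(-c2nc3c(c(C)nn3-c3ccccc3)c(-c3ccccc3O)c2C#N)cc1` gives 3100 nM
compound 2 `CCc1ccc(-c2nc3c(c(C)nn3-c3ccccc3)c(-c3ccccc3C#N)c2C#N)cc1` gives 2400 nM

Both compounds were run in a physicochemical assay for solubility, read by spectrophotometry, in phosphate buffer, with a stated time of 18 h, at pH 7.4; on this read-out lower numbers stand for lower solubility and higher numbers for higher solubility. Compound 1 gives 3100 nM and compound 2 gives 2400 nM; compound 2 has the lowest of the two numbers, yet the step of a 1.3-fold lower number from compound 1 to compound 2 (0.11 log units; within the scatter) lies within the scatter, so the two cannot really be told apart. Compound 3 `CCc1ccc(-c2nc3c(c(C)nn3-c3ccccc3)c(-c3ccccc3Br)c2C#N)cc1` has not been measured. It differs from compound 2 by bromo in place of cyano on an aromatic carbon. Among the measured compounds shown here, the one measured step concerns hydroxy giving way to cyano and was small; no measured step speaks to bromo replacing cyano, so there is no direct precedent. In the absence of one, a modest step is expected, if anything to a lower number, with a wide range. For compound 3 the estimate in this assay is 1500 nM, expected to fall between 500 nM and 4500 nM, which would mean a step of a 1.6-fold lower number from compound 2 to compound 3 (0.20 log units; within the scatter).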

Compound 3, solubility: 1500 nM
Beside the measured number, compound 3's estimate shows no gap at the digits printed; the measured number falls inside the stated range.
By their numbers in this assay, from the lowest: compounds 3, 2 and 1 (each within the scatter of the next, the first and the last beyond it).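

In this assay, bromo is a third group at this place, on an aromatic carbon ortho to a large group, and putting it in place of cyano gives a 1.6-fold lower number from compound 2 to compound 3 (0.20 log units; within the scatter) and leaves the two compounds indistinguishable. Among the compounds shown here, measured against hydroxy, bromo gives a 2.1-fold lower number from compound 1 to compound 3 (0.32 log units; beyond the scatter) and so provides the first step at this position to pass the scatter, although the step is only modest and the cyano compound cannot be separated from either neighbour. No measurement shown here offers an explanation for either step.

As far as these compounds go, whether an amine or a carboxylic acid at this same place would move the number well beyond the narrow span seen so far remains open. So does whether the small differences among hydroxy, cyano and bromo would carry over to any other version of the shared core.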